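Swapping the Charged Ring Head on a Seven-Carbon Chain

A few compounds are considered here, and "the series" means these few. Any claim that something is new, unique, unknown or untested is made for them only; others in the source may bear on it.

Compound 1 `Cc1cc(OCCCCCCC[N+]23CCN(CC2)CC3)cc(-n2cc(C(=O)Nc3cc(F)cc(F)c3)c(=O)c3ccc(N(C)C)nc32)c1` and compound 3 `Cc1cc(OCCCCCCC[N+]2(C)CCCC2)cc(-n2cc(C(=O)Nc3cc(F)cc(F)c3)c(=O)c3ccc(N(C)C)nc32)c1` share one core and differ in a single place: a group of 6 heavy atoms (5 carbon, 1 nitrogen; one five-membered non-aromatic ring with 1 hetero atom) in place of a group of 8 heavy atoms (6 carbon, 2 nitrogen; 2 six-membered non-aromatic rings with 2 hetero atoms each), on a saturated chain carbon, seven bonds along the chain from an oxygen on an aromatic ring. In an assay on LX2 cells for inhibition of COL1A1 promoter (Homo sapiens), read by a luciferase reporter, with a stated time of 24 h, tested at 50 uM (on this read-out lower numbers stand for a weaker effect and higher numbers for a stronger effect at the one concentration tested), compound 1 gives 5.52%, while compound 3 gives 35.4%. That exchange of ring heads makes the step of a number 29.9 percentage points higher from compound 1 to compound 3 (beyond the scatter). Compound 2 `Cc1ccc(-n2cc(C(=O)Nc3cc(F)cc(F)c3)c(=O)c3ccc(N(C)C)nc32)cc1OCCCCCCC[N+]12CCN(CC1)CC2` is built from the same atoms as compound 1 joined differently; the difference between the two cores is not broken down here. In this assay compound 2 gives 9.71%, a number within the scatter of compound 1. Compound 4 `Cc1ccc(-n2cc(C(=O)Nc3cc(F)cc(F)c3)c(=O)c3ccc(N(C)C)nc32)cc1OCCCCCCC[N+]1(C)CCCC1` is not yet measured and differs from compound 2 by the same change: a group of 6 heavy atoms (5 carbon, 1 nitrogen; one five-membered non-aromatic ring with 1 hetero atom) in place of a group of 8 heavy atoms (6 carbon, 2 nitrogen; 2 six-membered non-aromatic rings with 2 hetero atoms each), on a saturated chain carbon, seven bonds along the chain from an oxygen on an aromatic ring. Because the earlier pair showed a number 29.9 percentage points higher from compound 1 to compound 3 (beyond the scatter) for this change, a step of about that size, a number 28.3 percentage points higher from compound 2 to compound 4 (beyond the scatter), is expected. Compound 4 is accordingly estimated at 38%, between 18% and 58%.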

Compound 4, a percentage reported as inhibition, at one concentration (the size of the read-out at that concentration, not a potency): 55.9%
For compound 4 the middle estimate is 17.9 percentage points below the measured one, and the stated range covers the measured number.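

In this assay, replacing the two-ring head with the five-membered ring head on the core of compound 2 gives a number 46.2 percentage points higher from compound 2 to compound 4 (beyond the scatter) and so raises the number on both cores shown. The direction of the change carries over, but its size does not carry over exactly: the same change on two cores in this assay, a number 29.9 percentage points higher (beyond the scatter) from compound 1 to compound 3 and a number 46.2 percentage points higher (beyond the scatter) from compound 2 to compound 4, 16.3 percentage points apart, beyond the scatter of two such steps. Two pairs do not show that the change would act the same way on any other core, and they do not explain why the two steps differ in size.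

On these data alone, whether a longer chain, or a plain piperidine or morpholine in place of the charged head, would give a similar number remains open. Each number also comes from a single concentration, so it shows only a stronger or weaker effect at that concentration.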